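Naphthalene for methylphenyl on a benzyl-bearing core

The source may report more compounds than this note shows. Statements on the series, on what has been measured and on what is new or still open speak of the compounds shown alone.

Of the compounds shown here, three that share one core have been tested in a functional assay on SK-MEL-5 cells (Homo sapiens) for inhibition, read by sulforhodamine B assay, with a stated time of 48 h, tested at 10 uM; a lower number here means less inhibition, a higher number more inhibition at the concentration tested (going by the name of the read-out). Compound 1 `c1ccc2c(-c3cn4ccnc4c(-c4ccc5ncn(C6CCCCC6)c5c4)n3)cccc2c1` gives 4.06%, compound 2 `c1cn2cc(-c3ccsc3)nc(-c3ccc4ncn(C5CCCCC5)c4c3)c2n1` gives 25%, and compound 3 `Cc1cccc(-c2cn3ccnc3c(-c3ccc4ncn(Cc5ccccc5)c4c3)n2)c1` gives 10.1%. Among these three numbers compound 3 stands second highest: its nearest neighbour is compound 1, which lies within the scatter, and its furthest is compound 2, which lies beyond the scatter.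

Compound 4 `c1ccc(Cn2cnc3ccc(-c4nc(-c5cccc6ccccc56)cn5ccnc45)cc32)cc1` has not yet been measured. It differs from compound 3 in one place: naphthalen-1-yl in place of 3-methylphenyl on an aromatic carbon. Going by the values given here, the only measured step that touches the entering group is a number 20.9 percentage points higher from compound 1 to compound 2 (beyond the scatter), where the naphthalen-1-yl group left and a thiophen-3-yl group entered; compound 1, which carries the naphthalen-1-yl group, holds the lowest of the three numbers. Among the compounds with values here, no measured step compares naphthalen-1-yl with 3-methylphenyl directly, and the core of compound 4 carries a benzyl group rather than the cyclohexyl group of compound 1 and compound 2.

Given that the naphthalen-1-yl compound 1 reads 4.06%, compound 4 is expected to give a number that is low and close to that of compound 3, with a step of a number 4.1 percentage points lower from compound 3 to compound 4 (within the scatter) that stays within the scatter. The estimate for compound 4 in this assay is 6%, with a range from 0% to 18%.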

Compound 4, a percentage reported as inhibition, at one concentration (the size of the read-out at that concentration, not a potency): 9.69%
For compound 4 the middle estimate is 3.7 percentage points below the measured one, within the range that was stated.
By their numbers in this assay, from the lowest: compounds 1, 4 and 3 (each within the scatter of the next); then compound 2.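

On the benzyl-bearing core in this assay, the exchange at this aromatic carbon of the ring with 2 nitrogen gives a number 0.4 percentage points lower from compound 3 to compound 4 (within the scatter), so naphthalen-1-yl, with 10 heavy atoms and two aromatic rings, cannot be told apart here from 3-methylphenyl, with 7 heavy atoms and one ring. Going by these compounds alone, with naphthalen-1-yl held in place, the change on the aromatic nitrogen gives a number 5.6 percentage points higher from compound 1 to compound 4 (within the scatter), so benzyl in place of cyclohexyl also shifts the reading by no more than the scatter, and this is the first comparison of those two groups. No independent evidence bears on why these readings stay so close.

Thiophen-3-yl is shown only on the cyclohexyl-bearing core, so it remains open whether the step beyond the scatter seen for compound 2 would carry over to the benzyl-bearing core. Also open is how the reading would respond at this aromatic carbon to a phenyl ring carrying an amine or a carboxylic acid, for which the compounds shown offer no guide.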